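Quinoline ether triazole amides: compound 2 to compound 3

The source may report more compounds than this note shows. Statements on the series, on what has been measured and on what is new or still open speak of the compounds shown alone.

Measured so far:
compound 1 `COc1cc2c(Oc3ccc(NC(=O)c4nnn(-c5ccccc5)c4C)cc3F)ccnc2cc1OCCCN1CCCC1` — 130 nM
compound 2 `COc1cc2c(Oc3ccc(NC(=O)c4nnn(-c5ccccc5C)c4C)cc3F)ccnc2cc1OCCCN1CCC(C)CC1` — 520 nM

In a functional assay on HT-29 cells (Homo sapiens) for cytotoxicity, read by MTT assay, with a stated time of 72 h (on this read-out lower numbers stand for stronger inhibition and higher numbers for weaker inhibition), compound 2 gives 520 nM and stands as the higher of the two numbers recorded; compound 1 gives 130 nM, a gap that lies beyond the scatter. Compound 3 `COc1cc2c(Oc3ccc(NC(=O)c4nnn(-c5ccccc5)c4C)cc3F)ccnc2cc1OCCCN1CCC(C)CC1` is not yet measured. Compound 3 differs from compound 2 by hydrogen in place of methyl on an aromatic carbon, that is, 2-methylphenyl to phenyl. Among the compounds with values here, no single-change step is available to size this. The expectation is a moderate move toward a lower number, a 2.1-fold lower number from compound 2 to compound 3 (0.32 log units; beyond the scatter), possibly not beyond the scatter. Compound 3 is estimated at 250 nM, in the range 90 nM to 700 nM.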

Compound 3, half-maximal inhibitory concentration: 140 nM
For compound 3 the middle estimate is 1.8-fold (0.25 log units) above the measured one; the range from low to high includes it.
By their numbers in this assay, from the lowest: compounds 1 and 3 (each within the scatter of the next); then compound 2.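

In this assay, within the data shown here, hydrogen in place of methyl on the aromatic carbon gives a 3.7-fold lower number from compound 2 to compound 3 (0.57 log units; beyond the scatter), the first single-change reading at this position, with 4-methylpiperidin-1-yl held constant. With phenyl held constant, 4-methylpiperidin-1-yl in place of pyrrolidin-1-yl on the chain gives a 1.1-fold higher number from compound 1 to compound 3 (0.03 log units; within the scatter), so these two amines are not told apart in this assay. Nothing available explains either step.

Going by these compounds, whether the methyl step holds with pyrrolidin-1-yl on the chain stays open. So does the outcome of a chlorine atom or methoxy group on that aromatic carbon, or of morpholine as the chain amine.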